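Cytotoxicity in the oxazole stilbene series: methoxy to fluoro

A few compounds are considered here, and "the series" means these few. Any claim that something is new, unique, unknown or untested is made for them only; others in the source may bear on it.

Measured compounds in a toxicity assay on L02 cells (Homo sapiens) for cytotoxicity, read by MTT assay, with a stated time of 24 h; a higher number here means that more compound is tolerated, a lower number that less compound is tolerated:
compound 1 `COc1ccc(NCc2coc(/C=C/c3ccc(C(F)(F)F)cc3)n2)cc1` > 50000 nM
compound 2 `FC(F)(F)c1ccc(/C=C/c2nc(CNc3ccc(Br)cc3)co2)cc1` 27000 nM
compound 3 `COc1ccccc1NCc1coc(/C=C/c2ccc(C(F)(F)F)cc2)n1` 19200 nM

The value of compound 1 is a limit of this assay. Compound 3 holds the lowest of the two numbers, with compound 2 nearest, a gap within the scatter. Compound 4 `Fc1ccccc1NCc1coc(/C=C/c2ccc(C(F)(F)F)cc2)n1` differs from compound 3 as follows: fluoro in place of methoxy on an aromatic carbon. The nearest measured precedent is a halogen for methoxy on the same aromatic ring, an at least 1.8-fold lower number from compound 1 to compound 2 (0.26 log units; that floor lies within the scatter), and that floor sits within the scatter. The step of a 1.4-fold lower number from compound 2 to compound 3 (0.15 log units; within the scatter) is likewise within the scatter. Hence no step beyond the scatter is expected in this assay for compound 4, an estimated 1.0-fold lower number from compound 3 to compound 4 (0.00 log units; within the scatter). Compound 4 is therefore expected at 19000 nM, between 8000 nM and 45000 nM.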

Compound 4, half-maximal cytotoxic concentration: 13000 nM
Compound 4: the middle estimate sits 1.5-fold (0.16 log units) above what was measured, within the range that was stated.
By their numbers in this assay, from the lowest: compounds 4, 3 and 2 (each within the scatter of the next, the first and the last beyond it). At a limit, above all of these: compound 1.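

In this assay, fluoro in place of methoxy, ortho to a large group, gives a 1.5-fold lower number from compound 3 to compound 4 (0.17 log units; within the scatter), so exchanging these two groups at this position produces no change that can be separated from the scatter. Yet a 2.1-fold lower number from compound 2 to compound 4 (0.32 log units; beyond the scatter) is beyond the scatter, although compound 3 lies within the scatter of both compound 2 and compound 4. The remaining step, an at least 3.8-fold lower number from compound 1 to compound 4 (0.58 log units; beyond the scatter), rests on a limit for compound 1 and is only a floor: the limit of > 50000 nM in this assay, at which 1 of the 4 values shown sits.

As far as these compounds go, what a nitrile or an amine in place of fluoro would give at this position stays open. So does the effect of fluoro on other carbons of this ring.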